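Anilino-to-cycloalkylamino swap at the enaminone nitrogen

A few compounds are considered here, and "the series" means these few. Any claim that something is new, unique, unknown or untested is made for them only; others in the source may bear on it.

Measured compounds:
- compound 1 `Cc1ccc(NC2=CC(=O)c3nc4n(c3C2=O)[C@H]2OC[C@@H](O)[C@H]2OC4)cc1` gives 3480 nM in a functional assay on ECa-109 cells for inhibition, with ECa-109 cell line (Homo sapiens) as the target, read by sulforhodamine B assay; a higher number here means a weaker inhibitor, a lower number a stronger inhibitor
- compound 2 `Cc1ccc(NC2=CC(=O)c3nc4n(c3C2=O)[C@H]2OC[C@@H](O)[C@H]2OC4)cc1C` gives 2820 nM in this assay
- compound 3 `CCCc1ccc(NC2=CC(=O)c3c(nc4n3[C@H]3OC[C@@H](O)[C@H]3OC4)C2=O)cc1` reports a limit, > 4000 nM, in this assay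

The shared core carries an amine nitrogen whose other neighbour is a double-bonded ring carbon, and the three measured compounds vary only the group on that nitrogen. Compound 1 and compound 2 differ by methyl in place of hydrogen on an aromatic carbon; the step of a 1.2-fold lower number from compound 1 to compound 2 (0.09 log units; within the scatter) is small and within the scatter, so the two cannot be ordered. For compound 3 only a limit is known, and it sits at the limit of > 4000 nM in this assay, at which 1 of the 3 values shown sits; no number stands for it.

Compound 4 `O=C1C(NC2CCCC2)=CC(=O)c2c1nc1n2[C@H]2OC[C@@H](O)[C@H]2OC1` is not yet measured. It differs from compound 3 by cyclopentyl in place of 4-propylphenyl on an amine nitrogen. Among the measured compounds shown here, no measured step touches this kind of change: the one step available, from compound 1 to compound 2, is a methyl added on an aromatic ring, which says nothing about removing the aromatic ring itself. Compound 3 stands at the limit, so the starting point of the step is itself uncertain.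

Compound 4 is therefore expected to land near the limit as well, with the step that the limit leaves unreadable from compound 3 to compound 4 carrying little confidence in either direction. The estimate for compound 4 is 5000 nM, within 1500 nM to 15000 nM, and a limit rather than a number is as likely as not.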

Compound 4, half-maximal inhibitory concentration: > 16000 nM
Compound 4 ended at the assay's limit; the forecaster's own chance of this, stated with the estimate: 55%; middle value at least 3.2-fold (0.50 log units) from the limit.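

Compound 3 and compound 4 are both recorded only as limits, so the step between them cannot be read in size or direction. Left open is whether cyclopentyl in place of 4-propylphenyl on an amine nitrogen shifts the number either way, and how compound 4 truly stands against compound 1 and compound 2.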